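The source may hold more compounds than are shown below. What is called first, only, known or untested is meant among the compounds shown, and "the series" means these compounds.

Series notes. Compound 1 `COc1cc(C(=O)[n+]2cccc(C(=O)N3CCN(c4ccccc4Cl)CC3)c2)cc(OC)c1OC` and compound 2 `O=C(C1CCCN(Cc2ccccc2)C1)N1CCN(c2ccccc2Cl)CC1` have been run in a functional assay on a cell-free system (Platelet, plasma, Homo sapiens), with stated times of 4 min and 5.5 min, tested at 0.5 uM; a higher number here means a weaker effect of the compound at the concentration tested, a lower number a stronger effect. In this assay compound 1 gives 20%; compound 2 gives 26%, a number within the scatter of compound 1, so the two are taken as equal here. Compound 3 `O=C(C1CCCN(Cc2ccccc2F)C1)N1CCN(c2ccccc2Cl)CC1` is not yet measured. It differs from compound 2 in one place: fluoro in place of hydrogen on an aromatic carbon. Among the measured compounds shown here, no measured pair shows this change, so its effect is unknown. The expected step from compound 2 to compound 3 in this assay is a number 1 percentage points higher from compound 2 to compound 3 (within the scatter), none beyond the scatter. Compound 3 is therefore expected to give 27%, between 14% and 42%.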

Compound 3, a percentage reported as activity, at one concentration (the size of the read-out at that concentration, not a potency): 73%
Beside the measured number, compound 3's estimate is 46 percentage points below it; measured number above the stated range.
By their numbers in this assay, from the lowest: compounds 1 and 2 (each within the scatter of the next); then compound 3.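

In this assay the change from benzyl to 2-fluorobenzyl gives a number 47 percentage points higher from compound 2 to compound 3 (beyond the scatter), so the effect at the concentration tested is clearly weaker. This aromatic carbon, ortho to a large group, is therefore not indifferent to substitution: a single fluoro in place of hydrogen is enough to separate the two compounds. Nothing measured here accounts for the step.

Still open, going by these compounds, is whether a chloro or methoxy group on the same carbon gives a similar step, and whether fluoro on other carbons of this ring does the same.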